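Working notes: compound 4 from compound 3

The compounds below may be only part of what the source reports. "The series", "measured", "known", "first", "only" and "open" are said of these compounds alone.

Measured compounds:
compound 1, `Nc1ccccc1NC(=O)c1ccc(CSC(=S)N2CCN(Cc3ccccn3)CC2)cc1`: 82.4%
compound 2, `Nc1ccccc1NC(=O)c1ccc(CSC(=S)N2CCN(c3cccnc3)CC2)cc1`: 88.8%
compound 3, `CN1CCN(C(=S)SCc2ccc(C(=O)Nc3ccccc3N)cc2)CC1`: 91.6%

All three were read in a functional assay on A-375 cells (Homo sapiens) for antiproliferative activity, read by CCK-8 assay, with a stated time of 72 h, tested at 8 uM; on this read-out lower numbers stand for a weaker effect and higher numbers for a stronger effect at the one concentration tested. Compound 3 sits within the scatter of both others: a number 9.2 percentage points higher from compound 1 to compound 3 (within the scatter) and a number 2.8 percentage points higher from compound 2 to compound 3 (within the scatter), so no order among the three is established.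

Compound 4, `Nc1ccccc1NC(=O)c1ccc(CSC(=S)N2CCN(c3ccncc3)CC2)cc1`, differs from compound 3 by pyridin-4-yl in place of methyl on an amine nitrogen in a ring. Going by the values given here, two measured steps bear on this change. The closest is a number 2.8 percentage points higher from compound 2 to compound 3 (within the scatter), where pyridin-3-yl and methyl on the same ring nitrogen gave numbers within the scatter; a number 6.4 percentage points higher from compound 1 to compound 2 (within the scatter) also varied the group on that nitrogen without a step beyond the scatter. A step beyond the scatter in this assay is therefore not expected; the expected step is a number 3.6 percentage points lower from compound 3 to compound 4 (within the scatter).

Compound 4 is estimated at 88%, with a range from 78% to 95%.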

Compound 4, a percentage reported as inhibition, at one concentration (the size of the read-out at that concentration, not a potency): 90.7%
Compound 4: middle estimate off by 2.7 percentage points, on the low side; measured number inside the range.
By their numbers in this assay, from the lowest: compounds 1, 2, 4 and 3 (each within the scatter of the next).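

Pyridin-4-yl on the amine nitrogen in a ring gives no step beyond the scatter in this assay: a number 0.9 percentage points lower from compound 3 to compound 4 (within the scatter), a number 1.9 percentage points higher from compound 2 to compound 4 (within the scatter), and a number 8.3 percentage points higher from compound 1 to compound 4 (within the scatter). At this one concentration, the group therefore does not separate from methyl, pyridin-3-yl or (pyridin-2-yl)methyl. No measurement at hand offers an explanation for this result.

From the compounds shown here alone, whether a carboxylic acid, a primary amine or a longer chain on this nitrogen would give a step beyond the scatter remains open. Any order among these four compounds at lower concentrations also remains open.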